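The source may hold more compounds than are shown below. What is called first, only, known or untested is meant among the compounds shown, and "the series" means these compounds.

Measured compounds:
Compound 1, `COc1cc(/C=C/C(=O)C2=C(/C=C/c3ccc(O)c(OC)c3)NC(=O)NC2c2ccccc2Cl)ccc1O`: 20.2%
Compound 2, `COc1cc(/C=C/C(=O)C2=C(/C=C/c3ccc(O)c(OC)c3)NC(=S)NC2c2ccccc2)ccc1O`: 15.5%

Both compounds were tested in a functional assay, with a stated time of 20 min, tested at 2 uM; a lower number here means a weaker effect, a higher number a stronger effect of the compound at the concentration tested. In this assay compound 1 gives 20.2%, and compound 2 gives 15.5%. The two readings lie within the usual scatter of each other, so compound 2 cannot be set apart from compound 1 on these numbers; the pair simply marks the range in which compounds of this shared core have so far been found.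

Compound 3, `COc1cc(/C=C/C(=O)C2=C(/C=C/c3ccc(O)c(OC)c3)NC(=S)NC2c2ccccc2O)ccc1O`, has not yet been measured in this assay. It differs from compound 2 in one place: hydroxy in place of hydrogen on an aromatic carbon. The two compounds share everything else.

Among the compounds with values here, no step between measured compounds with this kind of change is available, so the direction of any effect cannot be read from the data. Compound 3 is therefore expected to stay close to compound 2, with a number 2.5 percentage points higher from compound 2 to compound 3 (within the scatter) estimated as no more than the scatter in either direction. The estimate for compound 3 in this assay is 18%, with a range from 5% to 35%.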

Compound 3, a percentage reported as activity, at one concentration (the size of the read-out at that concentration, not a potency): 25%
For compound 3 the middle estimate is 7 percentage points below the measured one, and the stated range covers the measured number.
By their numbers in this assay, from the lowest: compounds 2, 1 and 3 (each within the scatter of the next).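

Within the data shown here, the change from phenyl to 2-hydroxyphenyl provides the first direct comparison at this position: in this assay it gives a number 9.5 percentage points higher from compound 2 to compound 3 (within the scatter). Placing hydroxy on this aromatic carbon, ortho to a large group, therefore adds a hydrogen-bond donor and acceptor without producing a reading that can be set apart from that of the unsubstituted phenyl, so this single step establishes no gain or loss from the change. Nothing measured here explains the reading or bears on what the hydroxy group does at this position.

The compounds shown leave open whether any other group on this aromatic carbon, such as an amine, a carboxylic acid or a longer chain like ethoxy, would move the reading beyond the scatter. They also leave open whether the same hydroxy change would give a comparable step in a compound that differs elsewhere on the shared core, since this change has been read only once, between one pair of compounds.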